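Hydroxyphenyl imines: methyl where methoxy stood

A few compounds are considered here, and "the series" means these few. Any claim that something is new, unique, unknown or untested is made for them only; others in the source may bear on it.

Measured so far in an assay on isolated protein for inhibition of Amine oxidase [flavin-containing] B (Homo sapiens), read by fluorescence and Amplex Red, with stated times of 15 min and 20 min; on this read-out lower numbers stand for stronger inhibition and higher numbers for weaker inhibition:
- compound 1 `COc1ccc(O)c(/C=N/c2ccc(OCc3ccccc3)cc2)c1` gives 10700 nM
- compound 2 `Oc1ccccc1/C=N/c1ccc(OCc2ccccc2)cc1` gives 25100 nM

Among the compounds with values here, compound 2 stands at the higher of the two numbers; the only measured step, a 2.3-fold higher number from compound 1 to compound 2 (0.37 log units; beyond the scatter), is hydrogen in place of methoxy on an aromatic carbon. Compound 3 `Cc1ccc(O)c(/C=N/c2ccc(OCc3ccccc3)cc2)c1` is not yet measured. It differs from compound 2 by methyl in place of hydrogen on an aromatic carbon; the same difference cut one bond further out reads 2-hydroxyphenyl to 2-hydroxy-5-methylphenyl, the entering group meta to a large group and para to a hydroxy group. The methyl enters where compound 1 carries methoxy, so the step from compound 1 to compound 2 is the only one that bears on it; it was modest and beyond the scatter. On that single pair, a substituent at this place has gone with a lower number. Within the data shown here, the expected step is a 1.7-fold lower number from compound 2 to compound 3 (0.22 log units; within the scatter), modest and downward, with wide uncertainty since only one pair informs it. The estimate for compound 3 in this assay is 15000 nM, expected between 6000 nM and 40000 nM.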

Compound 3, half-maximal inhibitory concentration: 24600 nM
Beside the measured number, compound 3's estimate is 1.6-fold (0.21 log units) below it; the measured number falls inside the stated range.
By their numbers in this assay, from the lowest: compound 1; then compounds 3 and 2 (each within the scatter of the next).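

At this place, para to a hydroxy group, methyl in place of hydrogen gives a 1.0-fold lower number from compound 2 to compound 3 (0.01 log units; within the scatter) in this assay, so adding one carbon here does not separate the two compounds. Methyl in place of methoxy gives a 2.3-fold higher number from compound 1 to compound 3 (0.36 log units; beyond the scatter) and is close in size to hydrogen in place of methoxy, which gave a 2.3-fold higher number from compound 1 to compound 2 (0.37 log units; beyond the scatter) on the same read-out. The lower number seen with compound 1 therefore belongs to methoxy among the three groups shown, and a substituent at this place does not by itself go with a lower number, as compound 3 shows.

Going by these compounds, whether an ethoxy group, a chlorine atom or an amine at this place would read with methoxy or with methyl remains open. The data give no reason for the gap between methoxy and methyl here.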